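Methoxy for hydrogen on the pendant aryl ring

A few compounds are considered here, and "the series" means these few. Any claim that something is new, unique, unknown or untested is made for them only; others in the source may bear on it.

Within the data shown here, compound 2 `O=C1C[C@H](O)C[C@@H](/C=C/c2c(Cl)cc(Cl)cc2-c2ccccc2)O1` stands highest of the two numbers so far in an assay for inhibition of 3-hydroxy-3-methylglutaryl-coenzyme A reductase (Rattus norvegicus) (a lower number here means a stronger inhibitor, a higher number a weaker inhibitor), where compound 2 gives 80 nM. Compound 1 `Cc1cccc(-c2cc(Cl)cc(Cl)c2/C=C/[C@@H]2C[C@@H](O)CC(=O)O2)c1` gives 16 nM in this assay. Among the measured compounds shown here, the single step on record, a 5.0-fold higher number from compound 1 to compound 2 (0.70 log units; beyond the scatter), arose from hydrogen in place of methyl on an aromatic carbon. Compound 3 `COc1cccc(-c2cc(Cl)cc(Cl)c2/C=C/[C@@H]2C[C@@H](O)CC(=O)O2)c1` carries the change (methoxy in place of hydrogen on an aromatic carbon), which puts a group back on that carbon. Given the size of a 5.0-fold higher number from compound 1 to compound 2 (0.70 log units; beyond the scatter), the expected move for compound 3 is a 3.2-fold lower number from compound 2 to compound 3 (0.51 log units; beyond the scatter), toward a lower number. Compound 3 is estimated at 25 nM, within 8 nM to 80 nM.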

Compound 3, half-maximal inhibitory concentration: 50 nM
Compound 3: the middle estimate sits 2.0-fold (0.30 log units) below what was measured; the measured number falls inside the stated range.
By their numbers in this assay, from the lowest: compound 1; then compounds 3 and 2 (each within the scatter of the next).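

The step of a 1.6-fold lower number from compound 2 to compound 3 (0.20 log units; within the scatter) leaves methoxy and hydrogen on this aromatic carbon indistinguishable in this assay. The step of a 3.1-fold higher number from compound 1 to compound 3 (0.49 log units; beyond the scatter) is beyond the scatter, so at this position the methoxy group does not match the methyl group, and simply having a group on this carbon does not reproduce the value of compound 1. Nothing available explains this difference between methyl and methoxy.

Still open, going by these compounds, is whether ethyl, a longer chain than methyl, keeps the value of compound 1. On these data alone, how an amine or a chlorine atom on this carbon would compare also remains open.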